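Replacing phenoxymethyl with phenyl on the amide carbonyl

A few compounds are considered here, and "the series" means these few. Any claim that something is new, unique, unknown or untested is made for them only; others in the source may bear on it.

compound 1 `O=C(Nc1nnc(-c2cccc(O)c2O)s1)c1ccc(Cl)cc1`: 13000 nM
compound 2 `O=C(COc1ccccc1)Nc1nnc(-c2cccc(O)c2O)s1`: 117000 nM
compound 3 `O=C(COc1ccccc1)Nc1nnc(-c2ccc(O)c(O)c2)s1`: 51300 nM

In a functional assay on HeLa cells (Homo sapiens) for cytotoxicity, read by MTT assay, with a stated time of 72 h (a lower number here means a stronger inhibitor, a higher number a weaker inhibitor), compound 2 gives the highest of the three numbers. Compound 4 `O=C(Nc1nnc(-c2cccc(O)c2O)s1)c1ccccc1` differs from it as follows: phenyl in place of phenoxymethyl on a carbonyl carbon. The most relevant measured change is a 9.0-fold higher number from compound 1 to compound 2 (0.95 log units; beyond the scatter), which brought in phenoxymethyl in place of 4-chlorophenyl at that same carbon. The other measured change, a 2.3-fold lower number from compound 2 to compound 3 (0.36 log units; beyond the scatter), lies elsewhere in the structure and bears on this one only weakly. Phenyl is not 4-chlorophenyl, so only part of the larger step is expected to reverse, giving an expected 3.3-fold lower number from compound 2 to compound 4 (0.52 log units; beyond the scatter). The estimated value for compound 4 is 35000 nM, expected within 12000 nM to 100000 nM.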

Compound 4, half-maximal inhibitory concentration: 21800 nM
Beside the measured number, compound 4's estimate is 1.6-fold (0.21 log units) above it; measured number inside the range.
By their numbers in this assay, from the lowest: compounds 1 and 4 (each within the scatter of the next); then compound 3; then compound 2.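

On a carbonyl carbon, phenyl in place of phenoxymethyl gives a 5.4-fold lower number from compound 2 to compound 4 (0.73 log units; beyond the scatter) in this assay, so a lower number than that of compound 2 does not depend on the chloro group. Hydrogen in place of chloro on an aromatic carbon gives a 1.7-fold higher number from compound 1 to compound 4 (0.22 log units; within the scatter), so the chloro group makes no readable difference in this pair. No measurement on hand accounts for the phenyl and phenoxymethyl difference.

Open, from the compounds shown here alone, is whether a longer chain or an amine on that carbonyl carbon would hold the number of compound 4. Also open, going by these compounds, is whether 3,4-dihydroxyphenyl would shift the number with phenyl on the carbonyl as it does with phenoxymethyl.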